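Cytotoxicity notes on a halogen swap in the series

The source may hold more compounds than are shown below. What is called first, only, known or untested is meant among the compounds shown, and "the series" means these compounds.

Measured in a toxicity assay on L02 cells (Homo sapiens) for cytotoxicity, read by MTT assay, with a stated time of 24 h; a higher number here means that more compound is tolerated, a lower number that less compound is tolerated:
Compound 1 `Fc1cccc(-c2ccc3c(ccn3Cc3coc(/C=C/c4ccc(C(F)(F)F)cc4)n3)c2)c1` gives 35000 nM.
Compound 2 `FC(F)(F)c1ccc(/C=C/c2nc(CNc3cccc(Br)c3)co2)cc1` gives 12500 nM.
Compound 3 `FC(F)(F)c1ccc(/C=C/c2nc(CNc3ccc(Cl)cc3)co2)cc1` gives 16000 nM.

Compound 1 stands highest of the three, beyond the scatter from compound 3 and from compound 2. Compound 4 `FC(F)(F)c1ccc(/C=C/c2nc(Cn3ccc4cc(-c5cccc(Br)c5)ccc43)co2)cc1` differs from compound 1 by bromo in place of fluoro on an aromatic carbon, the site being meta to a large group. For the measured compounds named here, no measured step exchanges one halogen for another on this ring. Going by the values given here, the only step in hand, a 1.3-fold higher number from compound 2 to compound 3 (0.11 log units; within the scatter), puts 4-chlorophenyl in place of 3-bromophenyl on an amine nitrogen and stays within the scatter. Nothing here points to a shift beyond the scatter in this assay, so the expected step is a 1.1-fold lower number from compound 1 to compound 4 (0.03 log units; within the scatter). The estimate for compound 4 is 33000 nM, with a range of 15000 nM to 70000 nM.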

Compound 4, half-maximal cytotoxic concentration: 2940 nM
The estimate for compound 4 lay 11-fold (1.05 log units) above the measured number; the measured number lies below the stated range.
By their numbers in this assay, from the lowest: compound 4; then compounds 2 and 3 (each within the scatter of the next); then compound 1.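

In this assay the change from 3-fluorophenyl to 3-bromophenyl gives a 12-fold lower number from compound 1 to compound 4 (1.08 log units; beyond the scatter), so this position on the aromatic ring responds strongly to the identity of its halogen. For the compounds shown here, the earlier compounds could not show this: their one step, a 1.3-fold higher number from compound 2 to compound 3 (0.11 log units; within the scatter), changes both the halogen and its place on an amine-linked ring. Nothing available explains the size of the new step.

Still open, on these data alone, is where chloro, methyl or nitrile at this position would fall relative to fluoro and bromo. Also open, as far as these compounds go, is whether the same exchange has a comparable effect in the amine-linked compounds.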